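The source may hold more compounds than are shown below. What is called first, only, known or untested is meant among the compounds shown, and "the series" means these compounds.

Measured so far in a functional assay on Hep 3B2 cells (Homo sapiens) for cytotoxicity, read by sulforhodamine B assay, with a stated time of 48 h; a higher number here means a weaker inhibitor, a lower number a stronger inhibitor:
compound 1 `CCn1cc(-c2nc3ccccc3[nH]2)c(=O)c2cc(F)c(N3CCNCC3)cc21` gives > 10000 nM, which is a limit of the assay and not a number.
compound 2 `CCn1cc(-c2nc3ccccc3[nH]2)c(=O)c2cc(F)c(N3CCNCC3)nc21` gives 7800 nM.

Compound 1 therefore stands only at the limit of > 10000 nM in this assay, at which 1 of the 2 values shown sits, with no number of its own. Compound 3 `CCn1cc(-c2nc3ccc(Cl)cc3[nH]2)c(=O)c2cc(F)c(N3CCNCC3)cc21` has not been measured yet. It differs from compound 1 by chloro in place of hydrogen on an aromatic carbon. No measured step of this kind is shown here, so the expectation rests on compound 1 alone. The step from compound 1 to compound 3 in this assay is expected to be small, if anything toward a slightly stronger inhibitor, at about an at least 1.2-fold lower number from compound 1 to compound 3 (0.09 log units; that floor lies within the scatter). Compound 3 is thus estimated at 8000 nM, with a range from 3000 nM to 20000 nM.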

Compound 3, half-maximal inhibitory concentration: 2300 nM
The estimate for compound 3 lay 3.5-fold (0.54 log units) above the measured number; measured number outside the range, below it.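

Compound 3 shows that this aromatic carbon of the 1H-benzimidazol-2-yl group is not a silent spot: in this assay, chloro in place of hydrogen gives an at least 4.3-fold lower number from compound 1 to compound 3 (0.63 log units; beyond the scatter), a change beyond the usual scatter. The full size of this step cannot be read, as it starts from a limit and not from a number: the limit of > 10000 nM in this assay, at which 1 of the 3 values shown sits.

The compounds shown leave open whether fluoro, methyl, methoxy or an amine on this same carbon would lower the number as well. They also leave open what chloro would do on the core of compound 2.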